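Bromo for Chloro on the Aniline Ring of Compound 2

A few compounds are considered here, and "the series" means these few. Any claim that something is new, unique, unknown or untested is made for them only; others in the source may bear on it.

Measured so far:
- Compound 1 `O/N=C(/Nc1cccc(Br)c1)c1ccc2occc2c1`: in an assay on isolated protein for inhibition of Indoleamine 2,3-dioxygenase 1 (Homo sapiens), read by spectrophotometry (on this read-out lower numbers stand for stronger inhibition and higher numbers for weaker inhibition), compound 1 gives 440 nM.
- Compound 2 `O/N=C(/Nc1ccc(F)c(Cl)c1)c1ccc2occc2c1`: in this assay compound 2 gives 5200 nM.

Of the two numbers in hand, compound 2 holds the higher one, and the gap to compound 1 lies well beyond the usual scatter of this assay. Compound 3 `O/N=C(/Nc1ccc(F)c(Br)c1)c1ccc2occc2c1` has not yet been measured; it differs from compound 2 in one place: bromo in place of chloro on an aromatic carbon. Among the measured compounds shown here, no measured pair shows this exchange directly, so the size of the step is not known from the data. Compound 3 is expected to move modestly toward lower numbers, by a step of a 1.7-fold lower number from compound 2 to compound 3 (0.24 log units; within the scatter), which may not clear the scatter. Compound 3 is estimated at 3000 nM, within a range from 1000 nM to 9000 nM.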

Compound 3, half-maximal inhibitory concentration: 1600 nM
Compound 3: the middle estimate sits 1.9-fold (0.27 log units) above what was measured; the measured number falls inside the stated range.
By their numbers in this assay, from the lowest: compound 1; then compound 3; then compound 2.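

In this assay, among the compounds shown here, bromo in place of chloro on the aromatic carbon ortho to a fluoro group gives a 3.3-fold lower number from compound 2 to compound 3 (0.51 log units; beyond the scatter), the first direct reading of this exchange, and it shows that the choice between these two halogens at this place matters. With bromo kept, fluoro in place of hydrogen on an aromatic carbon gives a 3.6-fold higher number from compound 1 to compound 3 (0.56 log units; beyond the scatter), so this change also moves the number beyond the scatter, but in the opposite direction. Nothing given here accounts for the direction or size of either step.

The compounds shown leave open whether the exchange of chloro for bromo would give a step of similar size with no fluoro group on the ring. They also leave open how iodo, methyl or a nitrile would read at this same carbon.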